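This account rests on a few compounds, and the source may have more. Where it says the series, first, only, none or still open, it means among the compounds named here.

Working notes on the series

Of the compounds shown here, three sharing one core have been measured in a functional assay on HTB-54 cells (Homo sapiens) for cytotoxicity, read by MTT assay, with a stated time of 72 h; a lower number here means a stronger inhibitor of growth, a higher number a weaker inhibitor of growth. Compound 1, `COc1ccc(CNc2nc([SeH])nc3ccccc23)cc1`, gives 60900 nM in this assay. Compound 2, `C[Se]c1nc(N)c2ccccc2n1`, gives 88700 nM in this assay. Compound 3, `CCCCC[Se]c1nc(NCc2ccc(SC)cc2)c2ccccc2n1`, gives 81300 nM in this assay. For the measured compounds named here, compound 2 sits at the upper end of a tight cluster: its gaps to compound 3 and to compound 1 both lie within the usual scatter, so no order among the three can be read, and the set shows no step that separates one compound from another.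

Compound 4, `Nc1nc([SeH])nc2ccccc12`, has not yet been measured in this assay. It differs from compound 2 in one place: hydrogen in place of methyl on a selenium. Going by the values given here, no measured pair shows this change, so nothing in the data fixes its size or direction. Given that the three measured compounds, with quite different substitution, all fall within scatter of one another, the expectation is for no step beyond the scatter from compound 2 to compound 4. In this assay compound 4 is estimated at 75000 nM, in the range 30000 nM to 180000 nM, and the expected step is a 1.2-fold lower number from compound 2 to compound 4 (0.07 log units; within the scatter).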

Compound 4, concentration for total growth inhibition: 3630 nM
Beside the measured number, compound 4's estimate is 21-fold (1.32 log units) above it; measured number outside the range, below it.
By their numbers in this assay, from the lowest: compound 4; then compounds 1, 3 and 2 (each within the scatter of the next).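

In this assay, for the compounds shown here, hydrogen in place of methyl on a selenium gives a 24-fold lower number from compound 2 to compound 4 (1.39 log units; beyond the scatter), the first step beyond the scatter, so this one place can move the number strongly, which the earlier compounds did not reveal. Hydrogen on a selenium does not suffice by itself: compound 1 carries it too, along with a substituted benzyl group on the amine, and gives 60900 nM, while compound 4 gives 3630 nM. No measurement at hand accounts for the size of this step.

Going by these compounds, what remains open is how the number responds on the core of compound 4 to other groups on the selenium, such as an ethyl chain or an acetic acid chain. Also open, on these data alone, is whether small groups on the amine, such as methyl, keep the number of compound 4.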